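A few compounds are considered here, and "the series" means these few. Any claim that something is new, unique, unknown or untested is made for them only; others in the source may bear on it.

Working notes on the series. Compound 1 `CCOC(=O)c1oc2ccc(N(Cc3ccccc3)S(=O)(=O)c3cccc(Br)c3)cc2c1C` and compound 2 `CCOC(=O)c1oc2ccc(N(Cc3ccccc3)S(=O)(=O)c3cccc(Cl)c3)cc2c1C` share one core; compound 3 `Cc1c(C(=O)O)oc2ccc(N(Cc3ccccc3)S(=O)(=O)c3ccc(Br)cc3)cc12` and compound 4 `Cc1c(C(=O)O)oc2ccc(N(Cc3ccccc3)S(=O)(=O)c3ccc(Cl)cc3)cc12` share another. The difference between the two cores is not broken down here.

In a functional assay on HCT-116 cells (Homo sapiens) for inhibition, read by MTT assay, with a stated time of 72 h (on this read-out higher numbers stand for weaker inhibition and lower numbers for stronger inhibition), compound 1 reaches only a limit of the assay, > 40000 nM. Compound 2 likewise reaches only a limit, > 40000 nM. The change from compound 1 to compound 2 is chloro in place of bromo on an aromatic carbon; its step, a step that the two limits leave unreadable from compound 1 to compound 2, cannot be sized because both values sit at the limit of > 40000 nM in this assay, at which 2 of the 3 values shown sit. Among the compounds with values here, compound 3 gives 7090 nM in this assay, the only number among the three.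

The change from compound 3 to compound 4 is chloro in place of bromo on an aromatic carbon; it is the same kind of change as before, but the place differs: meta to a large group in compound 2, para to a large group in compound 4. With the measured step unreadable, compound 4 is expected to stay near compound 3, with an estimated step of a 1.3-fold higher number from compound 3 to compound 4 (0.10 log units; within the scatter). The estimate for compound 4 in this assay is 9000 nM, expected between 3500 nM and 25000 nM.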

Compound 4, half-maximal inhibitory concentration: 9130 nM
Compound 4: middle estimate off by 1.0-fold (0.01 log units), on the low side, within the range that was stated.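

In this assay, chloro in place of bromo on an aromatic carbon, para to a large group, gives a 1.3-fold higher number from compound 3 to compound 4 (0.11 log units; within the scatter), so the two halogens cannot be told apart on the core of compound 3. The same kind of change cannot be read on the core of compound 1, so nothing here shows that the result carries from one core to the other: the limit of > 40000 nM in this assay, at which 2 of the 4 values shown sit. The place of the halogen on the ring also differs between the two pairs, so core and place are not separated.

Open, as far as these compounds go, is whether an amine or a longer chain in the halogen's place would shift the value. Also open is what the ethyl ester and the carboxylic acid each contribute, as no pair shown differs there alone.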